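Swapping Hydroxymethyl for a Methyltetrazole Ring

This account rests on a few compounds, and the source may have more. Where it says the series, first, only, none or still open, it means among the compounds named here.

Compound 1 `OCc1cc(-c2ccccc2)c2ccc(OCc3cccc(C4(O)CCOCC4)c3)cc2c1` gives 9 nM in a functional assay for inhibition, with Homo sapiens as the target; on this read-out higher numbers stand for weaker inhibition and lower numbers for stronger inhibition. Its close relative compound 2 `N#Cc1cc(-c2ccccc2)c2ccc(OCc3cccc(C4(O)CCOCC4)c3)cc2c1` gives 3 nM in this assay. Among the compounds with values here, of these two numbers compound 1 has the highest, and the only step between them, a 3.0-fold lower number from compound 1 to compound 2 (0.48 log units; beyond the scatter), is a modest one beyond the scatter.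

Compound 3 `Cn1nnc(-c2cc(-c3ccccc3)c3ccc(OCc4cccc(C5(O)CCOCC5)c4)cc3c2)n1` differs from compound 1 in one place: 2-methyl-2H-tetrazol-5-yl in place of hydroxymethyl on an aromatic carbon. The step from compound 1 to compound 2 is the one that bears on this change, since there too the hydroxymethyl on the shared core gave way to a group with no hydrogen-bond donor, and the number fell modestly. The entering group here is larger, so the change is expected to go in the same direction but with no guarantee of the same size; a step of about a 1.8-fold lower number from compound 1 to compound 3 (0.26 log units; within the scatter) is expected. For compound 3 the value in this assay is therefore estimated at 5 nM, with a likely range from 1.5 nM to 15 nM.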

Compound 3, half-maximal inhibitory concentration: 4 nM
Compound 3: middle estimate off by 1.3-fold (0.10 log units), on the high side; low and high end bracket the measured number.
By their numbers in this assay, from the lowest: compounds 2 and 3 (each within the scatter of the next); then compound 1.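

Replacing hydroxymethyl with the 2-methyl-2H-tetrazol-5-yl ring gives a 2.3-fold lower number from compound 1 to compound 3 (0.35 log units; beyond the scatter) in this assay, so this position tolerates a five-membered aromatic ring of 6 heavy atoms, not only a small group. Compared with the nitrile, the ring gives a 1.3-fold higher number from compound 2 to compound 3 (0.12 log units; within the scatter), which means that these two quite different groups cannot be told apart on this read-out, although both lack the hydrogen-bond donor of hydroxymethyl and both give a lower number than compound 1. No measurement here explains why either replacement lowers the number.

From the compounds shown here alone, whether removing the hydrogen-bond donor matters, or whether some other difference between the groups does, remains open. A plain methyl, an amine or a carboxylic acid at this position would help separate these possibilities, as would a larger ring.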